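This account rests on a few compounds, and the source may have more. Where it says the series, first, only, none or still open, it means among the compounds named here.

Series notes. Compound 1 `CCCCn1nc(C(=O)N[C@H]2COc3ccccc3N(C)C2=S)nc1Cc1ccccc1`, compound 2 `CN1C(=S)[C@@H](NC(=O)c2nc(Cc3ccccc3)n(CCCF)n2)COc2ccccc21` and compound 3 `CN1C(=S)[C@@H](NC(=O)c2nc(Cc3ccccc3)n(CCCC#N)n2)COc2ccccc21` share one core and differ only in the chain carried on the aromatic nitrogen. In a toxicity assay on HT-29 cells (Homo sapiens) for cytotoxicity (on this read-out higher numbers stand for lower toxicity in this test and lower numbers for higher toxicity in this test), compound 1 gives > 100000 nM, which is a limit of the assay and not a number. Compound 2 likewise reaches only the limit > 100000 nM in this assay. Compound 3 also stands at the limit > 100000 nM in this assay. All three values thus sit together (the limit of > 100000 nM in this assay, at which 3 of the 3 values shown sit), and none is set apart from the others. Every step among them, a step that the two limits leave unreadable from compound 1 to compound 2, a step that the two limits leave unreadable from compound 1 to compound 3 and a step that the two limits leave unreadable from compound 2 to compound 3, has a limit at both ends and yields no readable size or direction.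

Compound 4 `CN1C(=S)[C@@H](NC(=O)c2nc(Cc3ccccc3)n(CC3COC3)n2)COc2ccccc21` differs from compound 3 by oxetan-3-yl in place of 2-cyanoethyl on a saturated chain carbon bound to an aromatic nitrogen. Going by the values given here, no measured step bears on this change with a readable size; the three steps known all run between limits. Nothing among compounds 1, 2 and 3 shows any departure from the limit when the chain on the aromatic nitrogen is varied (the limit of > 100000 nM in this assay, at which 3 of the 3 values shown sit). For compound 4 the step that the limit leaves unreadable from compound 3 to compound 4 is therefore expected to be none beyond the scatter in this assay. Compound 4 is estimated at 150000 nM in this assay, with a range from 50000 nM to 500000 nM, and is expected most likely to be reported again only as a limit.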

Compound 4, half-maximal cytotoxic concentration: > 100000 nM
Compound 4 was reported as a limit; the forecaster's own chance of this, stated with the estimate: 85%; the middle value does not contradict the limit.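

In this assay compound 4 gives > 100000 nM, which is a limit of the assay and not a number. Its steps from compound 1, compound 2 and compound 3 have a limit at both ends and cannot be read: the limit of > 100000 nM in this assay, at which 4 of the 4 values shown sit. The compounds shown leave open whether any chain on the aromatic nitrogen gives a measurable value in this assay.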